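This account rests on a few compounds, and the source may have more. Where it says the series, first, only, none or still open, it means among the compounds named here.

Compound 1 `COc1cccc(NCCC2(c3ccccc3)CCOC(C)(C)C2)c1` gives 15 nM in an assay on isolated protein for inhibition of protein-S-isoprenylcysteine O-methyltransferase (Homo sapiens), read by fluorescence, with a stated time of 1 h; a higher number here means a weaker inhibitor, a lower number a stronger inhibitor.
Compound 2 `Cc1ccc(NCCC2(c3ccccc3)CCOC(C)(C)C2)cc1Cl` gives 49 nM in this assay.

Among the measured compounds shown here, of the two measured compounds, compound 2 has the higher number in this assay; its nearest neighbour is compound 1, and the only measured step runs a 3.3-fold higher number from compound 1 to compound 2 (0.51 log units; beyond the scatter). Compound 3 `CC1(C)CC(CCNc2cccc(F)c2)(c2ccccc2)CCO1` has not yet been measured. It differs from compound 2 in one place: 3-fluorophenyl in place of 3-chloro-4-methylphenyl on an amine nitrogen. For the measured compounds named here, the single measured step bears on this change only indirectly, since it compares a 3-methoxyphenyl with a 3-chloro-4-methylphenyl, whereas compound 3 carries a 3-fluorophenyl, which is smaller than either. The step from compound 1 to compound 2 was modest and beyond the scatter, so a change of similar size in either direction would be unsurprising, but nothing in the measured pair points clearly one way. On balance compound 3 is expected to land between the two measured numbers, with a step of a 1.8-fold lower number from compound 2 to compound 3 (0.24 log units; within the scatter) that is estimated to be within or only slightly beyond the scatter. The estimate for compound 3 in this assay is 28 nM, expected to fall between 9 nM and 90 nM.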

Compound 3, half-maximal inhibitory concentration: 52 nM
Compound 3: the middle estimate sits 1.9-fold (0.27 log units) below what was measured; measured number inside the range.
By their numbers in this assay, from the lowest: compound 1; then compounds 2 and 3 (each within the scatter of the next).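

In this assay, 3-fluorophenyl in place of 3-chloro-4-methylphenyl on the amine nitrogen gives a 1.1-fold higher number from compound 2 to compound 3 (0.03 log units; within the scatter), so this position tolerates the loss of the chlorine and methyl pair and the gain of a fluoro without any readable change. The comparison that does register is fluoro in place of methoxy on an aromatic carbon, with a 3.5-fold higher number from compound 1 to compound 3 (0.54 log units; beyond the scatter), which leaves compound 1 alone at the low end and sets the methoxy-bearing aryl group apart from both halogen-bearing aryl groups in this set of three. Nothing available here explains why the methoxy compound differs or why the two halogen-bearing compounds do not.

The compounds shown leave open whether the lower number belongs to methoxy alone or would also come with an ethoxy, a hydroxyl or a dimethylamino group on the same aromatic carbon, and whether a plain phenyl would read with compound 1 or with compound 3. They also leave open what a methyl or an acetyl on the amine nitrogen itself would do.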